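Chain terminus in the series: dimethylamino to methoxy

A few compounds are considered here, and "the series" means these few. Any claim that something is new, unique, unknown or untested is made for them only; others in the source may bear on it.

Measured in a functional assay on OVCAR-8 cells (Homo sapiens) for antiproliferative activity; a higher number here means a weaker inhibitor, a lower number a stronger inhibitor:
- compound 1 `Cn1ncc(Cl)c1-c1cc(C(=O)N[C@@H]2CN[C@H](CCN3CCC(O)CC3)C[C@H]2c2ccc(Cl)c(Cl)c2)oc1Cl`: 15900 nM
- compound 2 `CN(C)CC[C@@H]1C[C@@H](c2ccc(Cl)c(Cl)c2)[C@H](NC(=O)c2cc(-c3c(Cl)cnn3C)c(Cl)o2)CN1`: 1510 nM

Compound 2 holds the lower of the two numbers. For the measured compounds named here, the only measured step is an 11-fold lower number from compound 1 to compound 2 (1.02 log units; beyond the scatter), a large one beyond the scatter, with dimethylamino in place of 4-hydroxypiperidin-1-yl on a saturated chain carbon.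

Compound 3 `COCC[C@@H]1C[C@@H](c2ccc(Cl)c(Cl)c2)[C@H](NC(=O)c2cc(-c3c(Cl)cnn3C)c(Cl)o2)CN1` changes the same place: methoxy in place of dimethylamino on a saturated chain carbon, two bonds along the chain from a saturated ring carbon, methoxy in place of dimethylamino. Going by the values given here, the step to compound 2 shows that this place can move this assay considerably, but no measured compound carries methoxy here, and both measured groups contain nitrogen. The direction therefore remains a judgement, and a moderate move to a higher number, smaller than the measured step, is expected. The expected change is a 2.3-fold higher number from compound 2 to compound 3 (0.37 log units; beyond the scatter). For compound 3 the estimated value is 3500 nM, with an expected range of 1200 nM to 11000 nM.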

Compound 3, half-maximal inhibitory concentration: 1060 nM
Estimate against measurement, compound 3: 3.3-fold (0.52 log units) above, and the stated range ends above it.
By their numbers in this assay, from the lowest: compounds 3 and 2 (each within the scatter of the next); then compound 1.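

In this assay, for the compounds shown here, methoxy in place of dimethylamino gives a 1.4-fold lower number from compound 2 to compound 3 (0.15 log units; within the scatter), so a chain ending in an oxygen group sits level with one ending in a nitrogen group at this place, which the two nitrogen-bearing termini of the earlier compounds could not show. Methoxy in place of 4-hydroxypiperidin-1-yl gives a 15-fold lower number from compound 1 to compound 3 (1.18 log units; beyond the scatter), so compound 1 now stands apart from two different termini, and nitrogen at the chain end does not by itself separate these compounds. No measurement on hand accounts for these numbers.

On these data alone, whether a chain ending in a plain hydrocarbon group, a primary amine or a carboxylic acid stays level with compound 2 and compound 3 remains open. Also open, as far as these compounds go, is whether a morpholine ring at the chain end follows compound 1 or these two compounds.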